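A few compounds are considered here, and "the series" means these few. Any claim that something is new, unique, unknown or untested is made for them only; others in the source may bear on it.

Compound 1 `O=C(Cc1ccccc1)NNC(=O)c1ccc([N+](=O)[O-])o1`: 2000 nM
Compound 2 `O=C(NNC(=O)c1ccc([N+](=O)[O-])o1)c1ccc2ccccc2c1`: 2000 nM
Compound 3 `N[C@@H](C(=O)NNC(=O)c1ccc([N+](=O)[O-])o1)c1ccccc1`: not yet measured

In a functional assay on MRC5 cells (Homo sapiens) for cytotoxicity (on this read-out lower numbers stand for higher toxicity in this test and higher numbers for lower toxicity in this test), compound 1 gives 2000 nM and compound 2 gives 2000 nM, so compound 1 stands level with compound 2, within the scatter. Among the measured compounds shown here, no step between measured compounds that differ in one place is available.

Compound 3 differs from compound 1 by amino in place of hydrogen on a saturated chain carbon bound to an aromatic carbon and a carbonyl carbon. The core of compound 1 is otherwise kept.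

The evidence for the size of this step is thin. The two measured compounds carry different groups on the shared core, yet compound 1 at 2000 nM matches compound 2 at 2000 nM. In this assay a modest step toward higher numbers is expected, possibly not beyond the scatter, and a step in the opposite direction cannot be excluded.

The expected change is a 1.5-fold higher number from compound 1 to compound 3 (0.18 log units; within the scatter). The estimated value for compound 3 is 3000 nM, with an expected range from 1000 nM to 12000 nM.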

Compound 3, half-maximal cytotoxic concentration: 14000 nM
Estimate against measurement, compound 3: 4.7-fold (0.67 log units) below, and the stated range ends below it.
By their numbers in this assay, from the lowest: compounds 1 and 2 (each within the scatter of the next); then compound 3.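

Working notes on the saturated chain carbon bound to an aromatic carbon and a carbonyl carbon: in this assay, amino in place of hydrogen at this place gives a 7.0-fold higher number from compound 1 to compound 3 (0.85 log units; beyond the scatter) and thus shows that the read-out responds to a change at this position, which compound 1 and compound 2 alone could not show. Among the compounds shown here, the direction is toward lower toxicity in this test, but this is a single step, so it sets no trend beyond this pair. Nothing measured here speaks to the cause of the step.

On these data alone, it remains open whether the step belongs to the amino group itself or would also appear with a hydroxyl group or a dimethylamino group at the same place. Also open, as far as these compounds go, are how the opposite configuration at this carbon would read in this assay and whether amino at this place would give a step of similar size on the core of compound 2, where no such saturated chain carbon is present and a methylene-linked analogue would be needed.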